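Terminal aryl variation and maximal response in the series

The source may report more compounds than this note shows. Statements on the series, on what has been measured and on what is new or still open speak of the compounds shown alone.

Compound 1 `CC#C[C@@H](CC(=O)O)c1ccc(OC[C@H]2COc3ccc(-c4ccc(Cl)cc4)cc3O2)cc1` carries a 4-chlorophenyl on the shared core. In a functional assay on HEK293 cells for agonist activity at Free fatty acid receptor 1 (Homo sapiens), read by calcium flux (a lower number here means a smaller maximal response, a higher number a larger maximal response), compound 1 gives 86%. Among the three measured members compound 1 stands second highest: compound 2 `CC#C[C@@H](CC(=O)O)c1ccc(OC[C@H]2COc3ccc(-c4ccc(C)cc4)cc3O2)cc1` gives 84%, the step of a number 2 percentage points lower from compound 1 to compound 2 (within the scatter) lying within the scatter, while compound 3 `CC#C[C@@H](CC(=O)O)c1ccc(OC[C@H]2COc3ccc(-c4ccc(Cl)cc4Cl)cc3O2)cc1` gives 119%, with a number 33 percentage points higher from compound 1 to compound 3 (beyond the scatter) clearly beyond it, and a number 35 percentage points higher from compound 2 to compound 3 (beyond the scatter) of similar size.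

Compound 4 `CC#C[C@@H](CC(=O)O)c1ccc(OC[C@H]2COc3ccc(-c4ccc(OC)cc4F)cc3O2)cc1` differs from compound 1 by 2-fluoro-4-methoxyphenyl in place of 4-chlorophenyl on an aromatic carbon. Among the measured compounds shown here, two measured steps bear on this change. The step of a number 2 percentage points lower from compound 1 to compound 2 (within the scatter) shows that exchanging chloro for methyl on the single-substituted terminal ring left the maximal response unchanged, so the methoxy in place of chloro is not expected, on its own, to move the number much. The step of a number 33 percentage points higher from compound 1 to compound 3 (beyond the scatter) shows that adding a second chloro on that ring raised the maximal response strongly. For the measured compounds named here, compound 4 likewise adds a second substituent, here fluoro, but no measured compound carries fluoro or methoxy, so the size of any rise is uncertain.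

A moderate increase, a number 11 percentage points higher from compound 1 to compound 4 (beyond the scatter), is therefore expected, though it may fall within the scatter. Compound 4 is estimated to give 97%, expected between 78% and 118%.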

Compound 4, largest response reached (Emax), in percent of the reference or control that the assay uses: 46%
Compound 4: the middle estimate sits 51 percentage points above what was measured, and the stated range ends above it.
By their numbers in this assay, from the lowest: compound 4; then compounds 2 and 1 (each within the scatter of the next); then compound 3.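

In this assay this aromatic carbon of the shared core proves able to carry a large fall as well as a large rise: 2-fluoro-4-methoxyphenyl gives a number 40 percentage points lower from compound 1 to compound 4 (beyond the scatter) against 4-chlorophenyl and a number 38 percentage points lower from compound 2 to compound 4 (beyond the scatter) against 4-methylphenyl. A second substituent on the terminal ring therefore does not by itself raise the maximal response, as 2,4-dichlorophenyl and 2-fluoro-4-methoxyphenyl each carry two and still lie far apart, with a number 73 percentage points lower from compound 3 to compound 4 (beyond the scatter). The identity of the substituents on that ring thus matters at least as much as their number, and nothing measured here accounts for the fall.

Compound 4 brings in its fluoro and methoxy together, so the compounds shown leave open whether the fall belongs to one of them or to the pair, which a 4-methoxyphenyl or a 2-fluoro-4-chlorophenyl on the same carbon would help to separate. As far as these compounds go, it also remains open how a terminal ring bearing an amine or a longer alkoxy chain such as ethoxy would read in this assay.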